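The source may report more compounds than this note shows. Statements on the series, on what has been measured and on what is new or still open speak of the compounds shown alone.

Measured so far:
compound 1, `COCC(C(=O)N1CCN(c2cccc(C(F)(F)F)c2)CC1)N1C(=O)CCC1=O`: 100%
compound 2, `CCC(C(=O)N1CCN(c2cccc(C)c2)CC1)N1C(=O)CCC1=O`: 50%

In a functional assay on the whole organism (strain Swiss) with Mus musculus as the target, in the maximal electroshock model, with a stated time of 0.25 h, at a dose of 100 mg/kg by the intraperitoneal route (a higher number here means a stronger effect of the compound at the dose given, a lower number a weaker effect), compound 1 gives 100%, the higher of the two numbers, while compound 2 gives 50%, a gap that lies beyond the usual scatter. The next compound is compound 3, `CC(C(=O)N1CCN(c2cccc(C(F)(F)F)c2)CC1)N1C(=O)CCC1=O`, which differs from compound 1 in one place: hydrogen in place of methoxy on a saturated chain carbon, two bonds along the chain from an amide-type nitrogen in a ring and a carbonyl carbon. Among the measured compounds shown here, no earlier pair shows what this particular change does. A modest downward step a number 25 percentage points lower from compound 1 to compound 3 (beyond the scatter) is expected, possibly beyond the scatter. Compound 3 is therefore expected to reach about 75%, with a likely range from 40% to 100%.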

Compound 3, a percentage reported as activity, at one dose (the size of the read-out at that dose, not a potency): 50%
Compound 3: the middle estimate sits 25 percentage points above what was measured; measured number inside the range.
By their numbers in this assay, from the lowest: compounds 2 and 3 (each within the scatter of the next); then compound 1.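

In this assay, putting hydrogen in place of methoxy on this saturated chain carbon gives a large loss of effect: a number 50 percentage points lower from compound 1 to compound 3 (beyond the scatter). Among the compounds shown here, this is the first direct comparison at this position, and it shows that with the rest of the molecule unchanged, the read-out at this dose depends on the group carried here. Nothing measured on hand explains the step.

Compound 2 differs from compound 3 in more than one place, so it cannot be used to judge this change. As far as these compounds go, whether an ethoxy group, a hydroxymethyl group or an amine here would behave like methoxy or like hydrogen remains open.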